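Working notes: cytotoxicity of the bridged diphenyl series

The compounds below may be only part of what the source reports. "The series", "measured", "known", "first", "only" and "open" are said of these compounds alone.

Among the compounds with values here, compound 1 `CN1CCN(CCC(=O)N2CCC3(N4CCN(C)CC4)CC(c4ccccc4)C2C(c2ccccc2)C3)CC1` is one of two compounds so far with a number in an ADME assay on L6 cells (Rattus norvegicus) for cytotoxicity; a lower number here means a stronger inhibitor, a higher number a weaker inhibitor. In this assay compound 1 gives 161000 nM, the higher of the two numbers. Within the data shown here, compound 2 `CN1CCN(CCC(=O)OC2CC3(N4CCCCC4)CC(c4ccccc4)C2C(c2ccccc2)C3)CC1` in this assay gives 23500 nM, and the gap between the two lies beyond the usual scatter; as the two structures differ in several places, no single step between them can be drawn.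

Compound 3 `CN1CCN(CCCN2CCC3(N4CCN(C)CC4)CC(c4ccccc4)C2C(c2ccccc2)C3)CC1` is the next compound to be measured in this assay. It differs from compound 1 in one place: 3-(4-methylpiperazin-1-yl)propyl in place of (2-(4-methylpiperazin-1-yl)ethyl)carbonyl on an amine nitrogen in a ring.

Among the measured compounds shown here, no measured step in this assay covers a change of this kind, so the direction rests on judgement alone. A moderate move toward a lower number, beyond the scatter, is expected from compound 1 to compound 3, a 2.0-fold lower number from compound 1 to compound 3 (0.30 log units; within the scatter). For compound 3 in this assay the estimate is 80000 nM, within a range from 25000 nM to 250000 nM.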

Compound 3, half-maximal inhibitory concentration: 47800 nM
The estimate for compound 3 lay 1.7-fold (0.22 log units) above the measured number; the measured number falls inside the stated range.
By their numbers in this assay, from the lowest: compound 2; then compound 3; then compound 1.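

In this assay the change on the amine nitrogen in a ring gives a 3.4-fold lower number from compound 1 to compound 3 (0.53 log units; beyond the scatter) when 3-(4-methylpiperazin-1-yl)propyl replaces (2-(4-methylpiperazin-1-yl)ethyl)carbonyl. Within the data shown here, this is the first single-place step, and it shows that this position responds to the change in the attached chain while the rest of the core of compound 1 stays the same. No measurement at hand accounts for the size or direction of this step.

Still open, on these data alone, is whether a shorter ethyl or longer butyl chain ending in 4-methylpiperazin-1-yl would continue this trend at the same nitrogen. Also open, as far as these compounds go, is whether a terminal morpholine or dimethylamino group in place of the 4-methylpiperazin-1-yl group would keep the number near that of compound 3.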